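This account rests on a few compounds, and the source may have more. Where it says the series, first, only, none or still open, it means among the compounds named here.

Series notes. Of the compounds shown here, three have been measured in an assay on HEK293 cells for displacement of a labelled ligand from Neuronal acetylcholine receptor; alpha4/beta2 (Homo sapiens); on this read-out higher numbers stand for weaker inhibition and lower numbers for stronger inhibition. Compound 1 `Clc1cncc(N2CCCNCCC2)c1` gives 2 nM in this assay. Compound 2 `COc1cc(N2CCNCC2)cnc1Br` gives 182 nM in this assay, and compound 3 `COc1cc(N2CCCNCC2)cnc1Cl` gives 0.676 nM in this assay. Of the three numbers, compound 1 has the second highest; compound 3 is nearest, with a number lower by a margin beyond the scatter, and compound 2 is furthest, with a number higher by a margin well beyond the scatter. No two of these compounds differ in a single place, so no single step between measured compounds is available.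

The step under consideration leads from compound 1 to compound 4 `COc1cncc(N2CCCNCCC2)c1`, not yet measured in this assay. The change is methoxy in place of chloro on an aromatic carbon. Among the measured compounds shown here, compounds 2 and 3 both carry a methoxy on their cores, but each also differs from compound 1 elsewhere, so their values show only that a methoxy-bearing core can sit anywhere from the lowest to the highest number in this set.

With nothing directly comparable, the expected step in this assay is a 3.0-fold higher number from compound 1 to compound 4 (0.48 log units; beyond the scatter), small and towards a higher number. For compound 4 the estimate in this assay is 6 nM, with a range of 1.5 nM to 25 nM.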

Compound 4, half-maximal inhibitory concentration: 1 nM
Estimate against measurement, compound 4: 6.0-fold (0.78 log units) above; the whole stated range lies above it.
By their numbers in this assay, from the lowest: compounds 3, 4 and 1 (each within the scatter of the next, the first and the last beyond it); then compound 2.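

In this assay, methoxy in place of chloro on this aromatic carbon, two atoms from the ring nitrogen, gives a 2.0-fold lower number from compound 1 to compound 4 (0.30 log units; within the scatter), so on the core of compound 1 the read-out does not separate the two groups. Among the compounds shown here, this is the first comparison that isolates the methoxy group, which compounds 2 and 3 could not do since each differs from compound 1 elsewhere as well. The hydrogen-bond acceptor counted on methoxy and absent from chloro therefore comes with no step beyond the scatter at this position, and no measurement at hand explains why the two groups read alike.

The compounds shown leave open whether other groups on this carbon, such as an amine, a carboxylic acid or a longer ethoxy chain, would also stay within the scatter of compound 1 or would move the number. They also leave open whether this exchange would read the same way on the cores of compound 2 and compound 3, which differ from compound 1 in more than one place.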